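A few compounds are considered here, and "the series" means these few. Any claim that something is new, unique, unknown or untested is made for them only; others in the source may bear on it.

Compound 1 `Cc1ccc(-c2c(CNC(C)(C)C)c(C(=O)O)nn2-c2ccccc2)cc1` is the starting point. In an ADME assay on HaCaT cells (Homo sapiens) for inhibition, read by sulforhodamine B assay, with a stated time of 48 h (a higher number here means a weaker inhibitor of growth, a lower number a stronger inhibitor of growth), compound 1 gives only a limit of the assay, > 688000 nM. Compound 2 `COc1ccc(-c2c(CNC(C)(C)C)c(C(=O)O)nn2-c2ccccc2)cc1` comes from compound 1 by methoxy in place of methyl on an aromatic carbon. In this assay compound 2 likewise reaches only a limit, > 659000 nM. Together this is a step that the two limits leave unreadable from compound 1 to compound 2. Compound 3 `Cc1ccc(-c2c(CNC(C)(C)C)c(C(=O)O)nn2-c2ccc(Cl)cc2)cc1` has a core differing from the core of compound 1 by chloro in place of hydrogen on an aromatic carbon. In this assay compound 3 again stops at a limit, > 629000 nM, so that a step that the two limits leave unreadable from compound 1 to compound 3. Compound 4 `COc1ccc(-c2c(CNC(C)(C)C)c(C(=O)O)nn2-c2ccc(Cl)cc2)cc1` differs from compound 3 by methoxy in place of methyl on an aromatic carbon, the same change as that from compound 1 to compound 2, at a place described in the same words. A step that the limit leaves unreadable from compound 3 to compound 4 is expected, resting on the fact that all three values shown sit at limits the limit of > 629000 nM in this assay, at which 1 of the 3 values shown sits, the limit of > 659000 nM in this assay, at which 1 of the 3 values shown sits (the limit of > 688000 nM in this assay, at which 1 of the 3 values shown sits). Compound 4 is thus estimated at 700000 nM.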

Compound 4, concentration for 50% growth inhibition: 121000 nM
Compound 4: middle estimate off by 5.8-fold (0.76 log units), on the high side; the measured number lies below the stated range.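

In this assay, methoxy in place of methyl on the core of compound 3 gives an at least 5.1-fold lower number from compound 3 to compound 4 (0.71 log units; beyond the scatter), and chloro in place of hydrogen gives an at least 5.4-fold lower number from compound 2 to compound 4 (0.73 log units; beyond the scatter). The same methoxy change on the core of compound 1 joins two limits of the assay, and neither that step nor the other step between two limits can be read, so carrying the change from one core to the other is neither confirmed nor ruled out. The size of the methoxy step is only a minimum, because compound 3 stands at a limit: the limit of > 629000 nM in this assay, at which 1 of the 4 values shown sits.

The compounds shown leave open how the number would move with ethoxy in place of the methoxy of compound 4, or with an amide in place of its carboxylic acid.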